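Swapping an Aryl Ring for an Amide Side Chain

The compounds below may be only part of what the source reports. "The series", "measured", "known", "first", "only" and "open" are said of these compounds alone.

Compound 1, `Fc1cc(F)cc(-c2nc(N3CCN(c4ncccc4C(F)(F)F)CC3)[nH]c2-c2ccc(C(F)(F)F)cc2)c1`, in a functional assay on CHO cells for antagonist activity at transient receptor potential cation channel subfamily V member 1 (Rattus norvegicus), read by calcium flux (on this read-out lower numbers stand for stronger inhibition and higher numbers for weaker inhibition), gives 35 nM.
Compound 2, `Fc1cc(-c2nc(N3CCN(c4ncccc4C(F)(F)F)CC3)[nH]c2-c2cc(F)c(F)c(F)c2)cc(F)c1F`, in this assay gives 44 nM.
Compound 3, `C[C@@H]1CN(c2ncccc2C(F)(F)F)CCN1c1nc(-c2ccccc2)c(-c2ccc(C(F)(F)F)cc2)[nH]1`, in this assay gives 117 nM.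

Compound 1 has the lowest number of the three. Compound 2 lies within the usual scatter of it, so the two cannot be told apart on these numbers. Compound 3 lies beyond the scatter, with a higher number, so compound 1 inhibits more strongly than compound 3.

Compound 4, `O=C(NCC1CCCCN1)c1nc(N2CCN(c3ncccc3C(F)(F)F)CC2)[nH]c1-c1ccc(C(F)(F)F)cc1`, has not yet been measured. It differs from compound 1 in one place: ((piperidin-2-yl)methyl)carbamoyl in place of 3,5-difluorophenyl on an aromatic carbon. For the measured compounds named here, all three measured compounds keep two aromatic rings on the shared core, so no measured pair shows what happens when one of those rings gives way to an amide chain. The expected step is a weakening of inhibition beyond the scatter, toward a higher number, estimated as a 23-fold higher number from compound 1 to compound 4 (1.36 log units; beyond the scatter). For compound 4 the estimate in this assay is 800 nM, with a range from 150 nM to 5000 nM.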

Compound 4, half-maximal inhibitory concentration: 2950 nM
Beside the measured number, compound 4's estimate is 3.7-fold (0.57 log units) below it; the measured number falls inside the stated range.
By their numbers in this assay, from the lowest: compounds 1 and 2 (each within the scatter of the next); then compound 3; then compound 4.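

Swapping 3,5-difluorophenyl for ((piperidin-2-yl)methyl)carbamoyl gives, in this assay, an 84-fold higher number from compound 1 to compound 4 (1.93 log units; beyond the scatter), a large step that lies beyond the scatter. This is the only pair shown that differs in one place, and it gives the first direct reading of this position, an aromatic carbon next to the ring nitrogen and next to the ring atom that bears a 4-(trifluoromethyl)phenyl group. On the shared core, inhibition at this receptor clearly depends on what occupies that carbon, and this amide side chain does not stand in for the aryl ring. The change alters the ring, the link to the core and the donor and acceptor counts all at once, and nothing shown here separates these parts or explains the loss.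

On these data alone, what remains open is whether the weakening follows from the amide link itself or from the piperidine at its end. A simple methyl amide, a carboxylic acid, a benzyl amide or a longer chain ending in an open-chain amine at this carbon could help separate those two parts.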